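Swapping the oxime ether for a hydroxyethyl group

The compounds below may be only part of what the source reports. "The series", "measured", "known", "first", "only" and "open" are said of these compounds alone.

Three compounds share a core and differ in the aryl ring and the group on the nitrogen. Compound 1 `CCCC(C)n1c(CC)nc2c(-c3ccc(/C(C)=N\OC)cc3Cl)ccnc21` gives 2.3 nM in an assay for binding affinity to Corticotropin releasing factor receptor (Rattus norvegicus) (on this read-out higher numbers stand for weaker inhibition and lower numbers for stronger inhibition), the highest of the three numbers. Compound 2 `CCCC(C)n1c(CC)nc2c(-c3ccc(OC)cc3C(F)(F)F)ccnc21` gives 0.74 nM, and compound 3 `CCc1nc2c(-c3ccc(Cl)cc3Cl)ccnc2n1[C@H](C)C1CC1` gives 0.6 nM; both of these gaps from compound 1 lie beyond the scatter, so compound 1 is the weakest binder of the three on this read-out.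

Compound 4 `CCCC(C)n1c(CC)nc2c(-c3ccc(C(C)O)cc3Cl)ccnc21` is the untested one. It keeps the core of compound 1 and changes the aryl ring: a group of 3 heavy atoms (2 carbon, 1 oxygen; no ring) in place of a group of 5 heavy atoms (3 carbon, 1 nitrogen, 1 oxygen; no ring), on an aromatic carbon. The departing group is larger and carries two acceptors, the incoming one is smaller and brings a donor.

Among the measured compounds shown here, no measured pair shows this exact change, so the expectation rests on compound 1 alone. The step of a 2.2-fold higher number from compound 1 to compound 4 (0.34 log units; beyond the scatter) is expected to be a modest move toward weaker binding, possibly no larger than the scatter. For compound 4 the estimate is 5 nM, with a range from 1.5 nM to 20 nM.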

Compound 4, inhibition constant: 5.1 nM
The estimate for compound 4 lay 1.0-fold (0.01 log units) below the measured number, within the range that was stated.
By their numbers in this assay, from the lowest: compounds 3 and 2 (each within the scatter of the next); then compound 1; then compound 4.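

Within this assay the change gives a 2.2-fold higher number from compound 1 to compound 4 (0.35 log units; beyond the scatter) as the first single-place step in this set, since compounds 2 and 3 each differ from compound 1 in more than one place. At this position, meta to a chloro group, the 1-hydroxyethyl group is therefore a modest step toward weaker binding, not a collapse of binding, even though the incoming group is smaller and brings a donor. No accompanying measurement explains this step, so the reason for it stays unknown.

This single swap changes size, donor count and acceptor count together, so it cannot show which of these matters. Going by these compounds, a 1-methoxyethyl group or an acetyl group at the same position would help separate them, and the two mirror-image forms of the 1-hydroxyethyl group also remain open.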